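Cytotoxicity notes: nitro to cyano on the benzyl arm

The source may hold more compounds than are shown below. What is called first, only, known or untested is meant among the compounds shown, and "the series" means these compounds.

Compound 1 `COC(=O)c1ccc(NCc2cncn2Cc2cccc([N+](=O)[O-])c2)cc1-c1ccccc1` is the reference point here. In a toxicity assay on NIH3T3 cells (Mus musculus) for cytotoxicity, read by resazurin assay (a higher number here means that more compound is needed for the effect, a lower number that less compound is needed), compound 1 gives > 10000 nM, which is a limit of the assay rather than a number. Compound 2 `N#Cc1ccc(NCc2cncn2Cc2ccc(-c3ccccc3)cc2N)cc1-c1ccccc1` and compound 3 `CC(C)c1ccc(Cn2cncc2CNc2ccc(-c3nc4ccccc4s3)c(-c3ccccc3)c2)cc1` belong to the same set. In this assay compound 2 gives > 1000 nM, again a limit and not a number. In this assay compound 3 gives > 1000 nM, also a limit. Compound 1 thus sits at the limit of > 10000 nM in this assay, at which 1 of the 3 values shown sits, while the other two sit at the limit of > 1000 nM in this assay, at which 2 of the 3 values shown sit; none of the three yields a number, so no ordering among them can be stated.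

Compound 4 `COC(=O)c1ccc(NCc2cncn2Cc2cccc(C#N)c2)cc1-c1ccccc1` is the next candidate. It differs from compound 1 as follows: cyano in place of nitro on an aromatic carbon. Within the data shown here, no step between measured compounds involves this change, and every value so far is a limit. For compound 4 the expected step that the limit leaves unreadable from compound 1 to compound 4 is none beyond the scatter. In this assay compound 4 is expected to give about 15000 nM, estimated within 5000 nM to 50000 nM, most probably reported again only as a limit.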

Compound 4, half-maximal effective concentration: > 10000 nM
Compound 4: no number, only a limit; the forecaster's own chance of this, stated with the estimate: 80%; the middle value lies beyond the limit too.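

In this assay compound 4 gives > 10000 nM, a limit and not a number. Among these compounds, compound 1 sits at that same limit, so no step from compound 1 to compound 4 can be read. The compounds shown leave open whether cytotoxicity in this series reaches a measurable value at all.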